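The source may hold more compounds than are shown below. What is called first, only, known or untested is meant among the compounds shown, and "the series" means these compounds.

Measured compounds:
compound 1 `O=S(=O)(NCCCNCc1ccc(C(F)(F)F)cc1)c1cc(C(F)(F)F)cc(C(F)(F)F)c1` gives 2700 nM
compound 2 `O=S(=O)(NCCCNCc1ccc(-c2ccccc2)cc1)c1cc(C(F)(F)F)cc(C(F)(F)F)c1` gives 2700 nM

In a functional assay on HPAC cells (Homo sapiens) for inhibition, read by MTT assay, with a stated time of 72 h (a higher number here means a weaker inhibitor of growth, a lower number a stronger inhibitor of growth), compound 1 is level with compound 2 at the digits shown; the step of no change at the digits printed from compound 1 to compound 2 (within the scatter) is within the scatter, so the two values show no difference that can be read as an order. The unmeasured compound 3 `O=S(=O)(NCCCNCc1cccc(Cl)c1)c1cc(C(F)(F)F)cc(C(F)(F)F)c1` differs from compound 1 by 3-chlorophenyl in place of 4-(trifluoromethyl)phenyl on a saturated chain carbon bound to an amine nitrogen, that is, from the 4-(trifluoromethyl)benzyl group to a 3-chlorobenzyl group. Within the data shown here, only one measured step bears on this, and only loosely: the change from compound 1 to compound 2 also rewrites the ring carried on the chain carbon bound to the amine nitrogen, and no change at the digits printed from compound 1 to compound 2 (within the scatter) left the growth inhibition unchanged within the scatter. Nothing measured here speaks to a chlorophenyl group, so the evidence is thin. On what is shown, compound 3 is expected to give 2700 nM, with a range of 1100 nM to 7000 nM. The expected step of no change at the digits printed from compound 1 to compound 3 (within the scatter) is therefore essentially none beyond the scatter.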

Compound 3, concentration for 50% growth inhibition: 2700 nM
Compound 3: the middle estimate sits on the measured number at the digits printed; the measured number falls inside the stated range.
By their numbers in this assay, from the lowest: compounds 1, 2 and 3 (each within the scatter of the next).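

In this assay the change from the 4-(trifluoromethyl)benzyl group to the 3-chlorobenzyl group gives no change at the digits printed from compound 1 to compound 3 (within the scatter) in growth inhibition. Where the earlier step replaced only the trifluoromethyl group with phenyl, this one replaces the whole 4-(trifluoromethyl)phenyl with 3-chlorophenyl, so the substituent and the number in the group's name both change, and the entering group has fewer heavy atoms than the group it replaces, yet the reading stays level across these three compounds. No measurement shown gives a reason for this flat reading, which therefore stays a bare observation about compound 1, compound 2 and compound 3.

The compounds shown leave open whether any group on this ring can move the value, since all three rings carry only carbon and halogen substituents, and a carboxylic acid, a primary amine or a nitrile there would test that. They also leave open whether the level reading would hold with a longer chain in the shared core or with an amide in place of the amine nitrogen.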